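Chloro on the fused ring of a 2-chloroquinoline stilbene series

The compounds below may be only part of what the source reports. "The series", "measured", "known", "first", "only" and "open" are said of these compounds alone.

Compound 1 `Fc1ccc(/C=C\c2cc3ccccc3nc2Cl)cc1` and compound 2 `Fc1ccc(/C=C\c2cc3ccc(Cl)cc3nc2Cl)cc1` share one core; compound 3 `FC(F)(F)c1cc(/C=C\c2cc3ccccc3nc2Cl)cc(C(F)(F)F)c1` and compound 4 `FC(F)(F)c1cc(/C=C\c2cc3ccc(Cl)cc3nc2Cl)cc(C(F)(F)F)c1` share another, and the difference between the two cores is not broken down here. In an ADME assay on 184B5 cells (Homo sapiens) for antiproliferative activity, read by sulforhodamine B assay, with a stated time of 72 h (a lower number here means a stronger inhibitor, a higher number a weaker inhibitor), compound 1 gives 35700 nM, compound 2 gives 26900 nM and compound 3 gives 13700 nM. The change chloro in place of hydrogen on an aromatic carbon moved the number a 1.3-fold lower number from compound 1 to compound 2 (0.12 log units; within the scatter). The same change, (chloro in place of hydrogen on an aromatic carbon), now leads from compound 3 to compound 4. Compound 4 is expected to move a 1.3-fold lower number from compound 3 to compound 4 (0.12 log units; within the scatter), because the same change produced a 1.3-fold lower number from compound 1 to compound 2 (0.12 log units; within the scatter) and nothing among these compounds suggests a different size on the second core. Compound 4 is therefore estimated at 10500 nM, within 5000 nM to 22000 nM in this assay.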

Compound 4, half-maximal inhibitory concentration: 43000 nM
For compound 4 the middle estimate is 4.1-fold (0.61 log units) below the measured one; the measured number lies above the stated range.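

In this assay, chloro in place of hydrogen on an aromatic carbon gives a 3.1-fold higher number from compound 3 to compound 4 (0.50 log units; beyond the scatter), whereas on the other core the same change gives a 1.3-fold lower number from compound 1 to compound 2 (0.12 log units; within the scatter). The effect of this change therefore did not carry from the core of compound 1 to the core of compound 3, and the two steps differ: the same change on two cores in this assay, a 1.3-fold lower number (0.12 log units; within the scatter) from compound 1 to compound 2 and a 3.1-fold higher number (0.50 log units; beyond the scatter) from compound 3 to compound 4, 4.2-fold (0.62 log units) apart, beyond the scatter of two such steps. This rests on a single pair per core, so it gives no reason for the difference and no forecast for any further core.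

Still open, from the compounds shown here alone, is whether a bromo group on the same aromatic carbon would follow the step seen on either core. The same question stands for an amine or a carboxylic acid there.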